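From amino to cyclopropylamino in the series

A few compounds are considered here, and "the series" means these few. Any claim that something is new, unique, unknown or untested is made for them only; others in the source may bear on it.

Within the data shown here, compound 1 `CN(Cc1ccc(Cl)cc1)c1cc(C(=O)Nc2ccccc2)ncn1` and compound 2 `COc1ccc(NC(=O)c2cc(N(C)Cc3ccc(Cl)cc3)nc(N)n2)cc1` are the two compounds measured so far in a physicochemical assay for solubility, using the shake flask method, measured as kinetic solubility, with a stated time of 2 h, at pH 7.4; a lower number here means a less soluble compound, a higher number a more soluble compound. Compound 1 gives < 5000 nM, which is a limit and not a number. Compound 2 gives < 5000 nM, also a limit. Compound 2 therefore has no exact position and shares this evidence with compound 1: the limit of < 5000 nM in this assay, at which 2 of the 2 values shown sit.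

Compound 3 `COc1ccc(NC(=O)c2cc(N(C)Cc3ccc(Cl)cc3)nc(NC3CC3)n2)cc1` has cyclopropyl in place of hydrogen on a nitrogen on an aromatic ring, the change from amino to cyclopropylamino: cyclopropyl in place of hydrogen on a nitrogen on an aromatic ring. Among the measured compounds shown here, no measured pair shows the size of such a change, so the expectation in this assay is loose: no step beyond the scatter, and probably another limit. The expected step is a step that the limit leaves unreadable from compound 2 to compound 3. For compound 3 the estimated value is 3000 nM, with an expected range of 1000 nM to 5000 nM.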

Compound 3, solubility: 5000 nM
Compound 3: middle estimate off by 1.7-fold (0.22 log units), on the low side, within the range that was stated.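

In this assay, among these compounds, compound 3 is the first compound of the series to give a number and not a limit, with cyclopropyl in place of hydrogen on a nitrogen on an aromatic ring. Compound 2 gives < 5000 nM as a limit and not a number. The change therefore reads only as a number no lower from compound 2 to compound 3 (the limit leaves the size open) and its size cannot be read because the value of compound 2 sits at the limit: the limit of < 5000 nM in this assay, at which 2 of the 3 values shown sit.

Going by these compounds, how far compound 2 actually lies from compound 3 stays open, so the contribution of cyclopropyl has no size yet. Also open, on these data alone, is whether a longer chain such as n-butyl, or a chain ending in a carboxylic acid, on that nitrogen would give a number in this assay and on which side of compound 3 it would fall.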